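The source may hold more compounds than are shown below. What is called first, only, known or untested is meant among the compounds shown, and "the series" means these compounds.

Compound 1, `Nc1cc(N)c2nc(-c3ccccc3)c(Oc3ccc(Cl)c(Cl)c3)nc2c1`, was tested in a functional assay on SK-MEL-28 cells (Homo sapiens) for inhibition, read by sulforhodamine B assay, with a stated time of 48 h; on this read-out lower numbers stand for higher toxicity in this test and higher numbers for lower toxicity in this test. In this assay compound 1 gives only a limit, < 100000 nM. Compound 3, `CCOC(=O)[C@H](CCC(=O)O)NC(=O)c1ccc(Sc2nc3cc(N)cc(N)c3nc2-c2ccccc2)cc1`, likewise returns only a limit in this assay, < 100000 nM. Among the compounds with values here, compound 2, `Nc1cc(N)c2nc(-c3ccccc3)c(NCc3ccc(Cl)c(Cl)c3)nc2c1`, is the one member of the set with a number rather than a limit, giving 93300 nM in this assay. Within the data shown here, compound 1 therefore cannot be placed above or below its neighbours: it sits at the limit of < 100000 nM in this assay, at which 2 of the 3 values shown sit, and the one numerical value, that of compound 2, lies close to that same limit.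

Compound 4, `Nc1cc(N)c2nc(-c3ccccc3)c(Sc3ccc(F)cc3)nc2c1`, has not yet been measured in this assay. It differs from compound 1 in one place: (4-fluorophenyl)sulfanyl in place of 3,4-dichlorophenoxy on an aromatic carbon. Among the measured compounds shown here, no measured pair in this set shows what such a change does. With compound 1 known only as a limit and compound 2 lying near it, the step from compound 1 to compound 4 is expected to stay within the scatter of the assay, a step that the limit leaves unreadable from compound 1 to compound 4, rather than to move in a clear direction. Compound 4 is accordingly estimated to give about 90000 nM in this assay, with a plausible range from 30000 nM to 200000 nM, and a real chance that only a limit is reported again.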

Compound 4, concentration lethal to 50% of the cells: < 100000 nM
Compound 4: no number, only a limit (the forecaster's own chance of this, stated with the estimate: 50%); the middle value does not contradict the limit.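

In this assay compound 4 gives < 100000 nM as a limit only. Within the data shown here, compound 1 is likewise known only as a limit, so no step between compound 1 and compound 4 can be read: the limit of < 100000 nM in this assay, at which 3 of the 4 values shown sit. The compounds shown leave open whether (4-fluorophenyl)sulfanyl in place of 3,4-dichlorophenoxy on this aromatic carbon changes the value at all, and in which direction.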